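Swapping the hydroxy of compound 3 for trifluoromethyl

The source may hold more compounds than are shown below. What is called first, only, known or untested is meant among the compounds shown, and "the series" means these compounds.

In a functional assay on HT-29 cells (Homo sapiens) for inhibition, read by luminescence and CellTiter-Glo, with a stated time of 24 h (a higher number here means that more compound is needed for the effect, a lower number that less compound is needed), compound 1 (`CN1C(=S)[C@@H](NC(=O)c2nc(Cc3ccccc3)n(C)n2)COc2ccccc21`), which carries methyl on the aromatic nitrogen, gives 2.5 nM. Compound 2 (`CC(C)n1nc(C(=O)N[C@H]2COc3ccccc3N(C)C2=S)nc1Cc1ccccc1`), with isopropyl there, gives 360 nM, and compound 3 (`CN1C(=S)[C@@H](NC(=O)c2nc(Cc3ccccc3)n(CCCO)n2)COc2ccccc21`), with 3-hydroxypropyl, gives 209 nM. Both changes are large: a 140-fold higher number from compound 1 to compound 2 (2.16 log units; beyond the scatter), and an 84-fold higher number from compound 1 to compound 3 (1.92 log units; beyond the scatter). The remaining pair is level, with a 1.7-fold lower number from compound 2 to compound 3 (0.24 log units; within the scatter), so compound 3 stands with compound 2, far above compound 1.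

Compound 4 (`CN1C(=S)[C@@H](NC(=O)c2nc(Cc3ccccc3)n(CCCC(F)(F)F)n2)COc2ccccc21`) keeps the chain of compound 3 but changes its end, with trifluoromethyl in place of hydroxy on a saturated chain carbon, three bonds along the chain from an aromatic nitrogen. The 3-hydroxypropyl group thus becomes 4,4,4-trifluorobutyl. For the measured compounds named here, no measured step makes this change at a chain end, so the evidence is indirect. The closest guide is the pair compound 2 and compound 3, whose different groups gave a 1.7-fold lower number from compound 2 to compound 3 (0.24 log units; within the scatter). On that basis, no step beyond the scatter is expected in this assay, and no return towards compound 1 is expected either, although the uncertainty is wide. The expected change is a 1.4-fold lower number from compound 3 to compound 4 (0.14 log units; within the scatter). For compound 4 the estimated value is 150 nM, with an expected range from 30 nM to 700 nM.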

Compound 4, half-maximal effective concentration: 2380 nM
Compound 4: middle estimate off by 16-fold (1.20 log units), on the low side, and the stated range ends below it.
By their numbers in this assay, from the lowest: compound 1; then compounds 3 and 2 (each within the scatter of the next); then compound 4.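

At this position the end of the chain counts, not only the group's attachment to the aromatic nitrogen: in this assay, trifluoromethyl in place of hydroxy gives an 11-fold higher number from compound 3 to compound 4 (1.06 log units; beyond the scatter) and so separates two compounds that share the same chain start. The level standing of compound 2 and compound 3 therefore does not mark a common level for all groups other than methyl on the aromatic nitrogen, since 4,4,4-trifluorobutyl in place of isopropyl gives a 6.6-fold higher number from compound 2 to compound 4 (0.82 log units; beyond the scatter) and lies clear of that pair. Methyl remains far ahead of all three, and the span at this nitrogen widens to a 950-fold higher number from compound 1 to compound 4 (2.98 log units; beyond the scatter) in this set of four compounds.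

On these data alone, whether an amine, a carboxylic acid or a plain butyl chain on this nitrogen would stand with compound 3 or with compound 4 remains open, as does whether ethyl there would stay close to compound 1. Nothing among the data shown gives a reason for the step from hydroxy to trifluoromethyl.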